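The compounds below may be only part of what the source reports. "The series", "measured", "known", "first", "only" and "open" are said of these compounds alone.

Compound 1 `COc1cc(OC)c(OC)cc1/C=C/C(=O)c1ccc(OC)c2c1OC(C)(C)C=C2`. In a functional assay on HepG2 cells (Homo sapiens) for antiproliferative activity, read by MTT assay, with a stated time of 24 h (on this read-out higher numbers stand for weaker inhibition and lower numbers for stronger inhibition), compound 1 gives > 10000 nM, a limit of the assay rather than a number.
Compound 2 `CCN(CC)c1ccc(/C=C/C(=O)c2ccc(OC)c3c2OC(C)(C)C=C3)cc1`. In this assay compound 2 gives 590 nM.
Compound 3 `COc1ccc(C(=O)/C=C/c2ccc(OC)c(OC)c2OC)c2c1C=CC(C)(C)O2`. In this assay compound 3 gives > 10000 nM, again a limit and not a number.

Among these three, compound 2 is the only one with an actual number; the other two sit at the limit of > 10000 nM in this assay, at which 2 of the 3 values shown sit, so no measured step between two real numbers exists here. Compound 4 `COc1ccc(C(=O)/C=C/c2ccc(Cl)cc2)c2c1C=CC(C)(C)O2` is built from compound 2 by one change: chloro in place of diethylamino on an aromatic carbon. Going by the values given here, since no measured pair shows what a change of this kind does, the expectation rests on compound 2 alone and on the fact that two related compounds gave only a limit. For compound 4 a step toward weaker inhibition is expected, of the size a 10-fold higher number from compound 2 to compound 4 (1.01 log units; beyond the scatter). Compound 4 is therefore estimated at 6000 nM, with a range from 1500 nM to 20000 nM, and there is a real chance that the assay reports only a limit.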

Compound 4, half-maximal inhibitory concentration: > 10000 nM
Compound 4: no number, only a limit; the forecaster's own chance of this, stated with the estimate: 40%; at least 1.6-fold (0.22 log units) between middle value and limit.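

In this assay, putting chloro in place of diethylamino on this aromatic carbon, para to a large group, gives an at least 16-fold higher number from compound 2 to compound 4 (1.22 log units; beyond the scatter). Compound 4 gives > 10000 nM, which is a limit of the assay and not a number. This is the first direct comparison at this position, and it shows that this single change is enough to take compound 2, the only compound here with a measured number, to the limit shared by the other compounds: the limit of > 10000 nM in this assay, at which 3 of the 4 values shown sit.

As far as these compounds go, how far the true value of compound 4 lies from that of compound 2 remains unknown, as a limit marks only where the reading stops. From the compounds shown here alone, it also remains open whether the nitrogen or the two ethyl chains matter more, a question that a plain amino group or dimethylamino at the same position could help to answer.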